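Methylation of the glycinamide nitrogen across two cores

The compounds below may be only part of what the source reports. "The series", "measured", "known", "first", "only" and "open" are said of these compounds alone.

Compound 1 `CNCC(=O)Nc1cc(OC)ccc1C(=O)c1ccc2c(c1)C=CC(C)(C)O2` and compound 2 `COc1ccc(C(=O)c2ccc3c(c2)C=CC(C)(C)O3)c(NC(=O)CN(C)C)c1` share one core; compound 3 `C=C(c1ccc(OC)cc1NC(=O)CN)c1ccc(OC)c2c1C=CC(C)(C)O2` and compound 4 `C=C(c1ccc(OC)cc1NC(=O)CNC)c1ccc(OC)c2c1C=CC(C)(C)O2` share another. The difference between the two cores is not broken down here. In a functional assay on MCF7 cells (Homo sapiens) for antiproliferative activity, read by MTT assay, with a stated time of 48 h (a higher number here means a weaker inhibitor, a lower number a stronger inhibitor), compound 1 gives 1210 nM, compound 2 gives 3560 nM and compound 3 gives 780 nM. Compound 3 and compound 1 lie within the scatter of each other; compound 3 and compound 2 do not.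

The change from compound 1 to compound 2 is methyl in place of hydrogen on an amine nitrogen, on an amine nitrogen whose other neighbours are two saturated chain carbons, and it made a 2.9-fold higher number from compound 1 to compound 2 (0.47 log units; beyond the scatter). The change from compound 3 to compound 4 is methyl in place of hydrogen on an amine nitrogen, on an amine nitrogen whose other neighbour is one saturated chain carbon. The two are the same kind of change, not the same.

Beside the measured step, a step of a 1.9-fold higher number from compound 3 to compound 4 (0.28 log units; within the scatter) in this assay is expected, resting on compound 1 giving 1210 nM against compound 2 giving 3560 nM, with wider uncertainty since the cores differ. Compound 4 is estimated at 1500 nM, between 600 nM and 4000 nM.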

Compound 4, half-maximal inhibitory concentration: 1010 nM
Beside the measured number, compound 4's estimate is 1.5-fold (0.17 log units) above it, and the stated range covers the measured number.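

In this assay, methyl in place of hydrogen on an amine nitrogen gives a 1.3-fold higher number from compound 3 to compound 4 (0.11 log units; within the scatter), so on this core the step cannot be told apart from repeat measurement. Set beside the step on the other core, the change shows no measurable difference in size between the two cores: the same change on two cores in this assay, a 2.9-fold higher number (0.47 log units; beyond the scatter) from compound 1 to compound 2 and a 1.3-fold higher number (0.11 log units; within the scatter) from compound 3 to compound 4, 2.3-fold (0.36 log units) apart, within the scatter of two such steps. Within the data shown here, this does not show that the step is the same on both cores or that it would hold on a further core, since each core supplies a single pair, only one of the two steps lies beyond the scatter, and the amine nitrogen has two saturated chain carbons as its other neighbours in one pair and one in the other.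

Still open, from the compounds shown here alone, is whether a dimethylamino end on the core of compound 3 would match the nitrogen change seen in the other pair more closely. Also open, going by these compounds, is how a longer chain, such as ethyl on the amine nitrogen, would compare on either core.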